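The source may hold more compounds than are shown below. What is called first, only, known or untested is meant among the compounds shown, and "the series" means these compounds.

Measured compounds:
Compound 1 `COc1ccc(C(=O)/C=C/c2ccc(F)cc2)c2c1C=CC(C)(C)O2`: in a functional assay on HCT-116 cells (Homo sapiens) for antiproliferative activity, read by MTT assay, with a stated time of 24 h (a lower number here means a stronger inhibitor, a higher number a weaker inhibitor), compound 1 gives > 10000 nM, which is a limit of the assay.
Compound 2 `COc1ccc(C(=O)/C=C/c2ccc(N(c3ccccc3)c3ccccc3)cc2)c2c1C=CC(C)(C)O2`: compound 2 gives > 10000 nM, again a limit.
Compound 3 `COc1ccc(C(=O)/C=C/c2ccc(C(F)(F)F)cc2)c2c1C=CC(C)(C)O2`: compound 3 gives > 10000 nM, also a limit.

Compound 1 stands only at a limit, as do the two further values shown, (the limit of > 10000 nM in this assay, at which 3 of the 3 values shown sit). The change to compound 4 `COc1ccc(C(=O)/C=C/c2cccs2)c2c1C=CC(C)(C)O2` is thiophen-2-yl in place of 4-fluorophenyl on a double-bonded chain carbon bound to a double-bonded chain carbon. Within the data shown here, the one step measured on this core, a step that the two limits leave unreadable from compound 1 to compound 3, runs between two limits and its size cannot be read. Among the measured compounds shown here, no measured step bears on the exchange of the aromatic ring at this position. Compound 4 is therefore expected to sit near the same limit, with the step that the limit leaves unreadable from compound 1 to compound 4 estimated as none beyond the scatter. Compound 4 is estimated at 15000 nM, between 5000 nM and 50000 nM, most likely again reported only as a limit.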

Compound 4, half-maximal inhibitory concentration: > 10000 nM
Compound 4 was reported as a limit (the forecaster's own chance of this, stated with the estimate: 80%); the middle value does not contradict the limit.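

No step from compound 1 to compound 4 can be read, since both stand only at a limit: the limit of > 10000 nM in this assay, at which 4 of the 4 values shown sit.

The compounds shown leave open which change to the shared core, if any, would give a value inside the range of the assay.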